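Shared change applied on a second core

This account rests on a few compounds, and the source may have more. Where it says the series, first, only, none or still open, it means among the compounds named here.

Measured compounds:
compound 1 `CN(C(=O)NC(=O)c1ccc(F)c(F)c1)c1nc(C(F)(F)F)c(C(=O)N/N=C/c2ccc(C(F)(F)F)cc2)s1` — 5.93 ug/mL
compound 2 `CN(C(=O)NC(=O)c1ccc(C(F)(F)F)cc1)c1nc(C(F)(F)F)c(C(=O)N/N=C/c2ccc(C(F)(F)F)cc2)s1` — limit, > 100 ug/mL
compound 3 `CN(C(=O)NC(=O)c1ccc(C(F)(F)F)cc1)c1nc(C(F)(F)F)c(C(=O)N/N=C/c2cccc(C(F)(F)F)c2)s1` — 8.95 ug/mL

In a functional assay on MCF7 cells (Homo sapiens) for inhibition, read by MTT assay, with a stated time of 72 h (on this read-out lower numbers stand for stronger inhibition and higher numbers for weaker inhibition), compound 1 gives 5.93 ug/mL. Compound 2 reaches only a limit of the assay, > 100 ug/mL; this is the limit of > 100 ug/mL in this assay, at which 1 of the 3 values shown sits. Compound 3 gives 8.95 ug/mL; its value and that of compound 1 lie within the scatter of each other.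

The change 3,4-difluorophenyl in place of 4-(trifluoromethyl)phenyl on a carbonyl carbon produced an at least 16-fold lower number from compound 2 to compound 1 (1.22 log units; beyond the scatter). The two cores differ as 3-(trifluoromethyl)phenyl in place of 4-(trifluoromethyl)phenyl on a carbon with a double bond to nitrogen, which gave an at least 11-fold lower number from compound 2 to compound 3 (1.04 log units; beyond the scatter).

Compound 4 `CN(C(=O)NC(=O)c1ccc(F)c(F)c1)c1nc(C(F)(F)F)c(C(=O)N/N=C/c2cccc(C(F)(F)F)c2)s1` carries the same change, (3,4-difluorophenyl in place of 4-(trifluoromethyl)phenyl on a carbonyl carbon), on the core of compound 3; the place is the same in both cases. Because compound 3 already gives 8.95 ug/mL, a smaller step than an at least 16-fold lower number from compound 2 to compound 1 (1.22 log units; beyond the scatter) is expected. The expected step is a 1.8-fold lower number from compound 3 to compound 4 (0.25 log units; within the scatter). Compound 4 is estimated at 5 ug/mL, expected between 1.5 ug/mL and 15 ug/mL.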

Compound 4, half-maximal inhibitory concentration: 4.15 ug/mL
For compound 4 the middle estimate is 1.2-fold (0.08 log units) above the measured one; the measured number falls inside the stated range.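

In this assay, 3,4-difluorophenyl in place of 4-(trifluoromethyl)phenyl on the carbonyl carbon gave a 2.2-fold lower number from compound 3 to compound 4 (0.33 log units; beyond the scatter), so the lower number carried over to the second core, but the size of the step did not: the same change on two cores in this assay, an at least 16-fold lower number (1.22 log units; beyond the scatter) from compound 2 to compound 1 and a 2.2-fold lower number (0.33 log units; beyond the scatter) from compound 3 to compound 4, at least 7.8-fold (0.89 log units) apart, beyond the scatter of two such steps. The change from 4-(trifluoromethyl)phenyl to 3-(trifluoromethyl)phenyl gave a 1.4-fold lower number from compound 1 to compound 4 (0.16 log units; within the scatter), and its size also depended on the core: the same change on two cores in this assay, an at least 11-fold lower number (1.04 log units; beyond the scatter) from compound 2 to compound 3 and a 1.4-fold lower number (0.16 log units; within the scatter) from compound 1 to compound 4, at least 7.8-fold (0.89 log units) apart, beyond the scatter of two such steps. On these data alone, compound 2 gives only a limit of the assay, > 100 ug/mL, and the true size of its two steps remains unknown.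

The compounds shown leave open whether a plain phenyl, or a phenyl bearing an amine or a carboxylic acid, on that carbonyl carbon would follow the same course on both cores.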